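This account rests on a few compounds, and the source may have more. Where it says the series, first, only, none or still open, it means among the compounds named here.

Working notes on the series. Among the measured compounds shown here, compound 1 `O=C(Nc1ccc(Oc2ccnc3[nH]ccc23)cc1)c1nn(-c2ccccc2)ccc1=O` gives 10500 nM in a functional assay on A549 cells (Homo sapiens) for cytotoxicity, read by MTT assay, with a stated time of 72 h (a higher number here means a weaker inhibitor, a lower number a stronger inhibitor), and compound 2 `O=C(Nc1ccc(Oc2ccnc3[nH]ccc23)cc1)c1nn(-c2ccc(Cl)c(F)c2)ccc1=O` gives 2580 nM; the only step measured so far is a 4.1-fold lower number from compound 1 to compound 2 (0.61 log units; beyond the scatter). Compound 2 thus stands at the lowest of the two numbers. Compound 3 `Cn1ccc2c(Oc3ccc(NC(=O)c4nn(-c5ccc(Cl)c(F)c5)ccc4=O)cc3)ccnc21` differs from compound 2 by methyl in place of hydrogen on an aromatic nitrogen, on the aromatic nitrogen of the five-membered ring in the fused system. For the measured compounds named here, no measured step touches that position, so nothing here bears directly on the change, and a step no larger than the scatter is expected. Compound 3 is therefore estimated at 2600 nM, range 800 nM to 8500 nM, a step of a 1.0-fold higher number from compound 2 to compound 3 (0.00 log units; within the scatter).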

Compound 3, half-maximal inhibitory concentration: > 60000 nM
Compound 3: a limit, no number; the forecaster's own chance of this, stated with the estimate: 5%; middle value at least 23-fold (1.36 log units) from the limit.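

In this assay, methyl in place of hydrogen on the aromatic nitrogen of the five-membered ring gives an at least 23-fold higher number from compound 2 to compound 3 (1.36 log units; beyond the scatter). The reading for compound 3 is a limit and not a number: the limit of > 60000 nM in this assay, at which 1 of the 3 values shown sits. This position is therefore sensitive to a single added carbon, which a 4.1-fold lower number from compound 1 to compound 2 (0.61 log units; beyond the scatter), made elsewhere in the molecule, could not reveal.

The compounds shown leave open whether the loss goes with the missing hydrogen or with the methyl itself. Going by these compounds, how an ethyl, a longer chain or an aminoethyl group on this nitrogen would read also remains open.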